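Cyclohexyl for Cyclopentyl on an Inactive Hydroxyurea Series

The source may hold more compounds than are shown below. What is called first, only, known or untested is meant among the compounds shown, and "the series" means these compounds.

Measured compounds:
compound 1 `CC(C)C(NC(=O)NO)C(=O)NC1CCCCC1` with > 100000 nM
compound 2 `CC(C)C(NC(=O)NO)C(=O)NC1CCCC1` with > 200000 nM
compound 3 `CC(C)C(NC(=O)n1nnc2ccccc21)C(=O)NC1CCCC1` with > 200000 nM

In a functional assay on CCRF-CEM cells (Homo sapiens) for inhibition (on this read-out higher numbers stand for weaker inhibition and lower numbers for stronger inhibition), compound 1 gives > 100000 nM, which is a limit of the assay. Compound 2 gives > 200000 nM in this assay, also a limit. For compound 3 the value > 200000 nM is a limit as well. The step that the two limits leave unreadable from compound 2 to compound 1 is the change (cyclohexyl in place of cyclopentyl on an amide-type nitrogen); the two limits, the limit of > 100000 nM in this assay, at which 1 of the 3 values shown sits, and (the limit of > 200000 nM in this assay, at which 2 of the 3 values shown sit), leave its size unreadable. Compound 4 `CC(C)C(NC(=O)n1nnc2ccccc21)C(=O)NC1CCCCC1` has not yet been measured in this assay. It differs from compound 3 by cyclohexyl in place of cyclopentyl on an amide-type nitrogen, the same change seen between compound 2 and compound 1. How the core of compound 3 differs from that of compound 2 is not broken down here.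

Since the three values are all limits, the step that the limit leaves unreadable from compound 3 to compound 4 is expected to remain within the unreadable range. Compound 4 is therefore estimated at 250000 nM, between 50000 nM and 1000000 nM, most likely reported as a limit.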

Compound 4, half-maximal inhibitory concentration: 112000 nM
For compound 4 the middle estimate is 2.2-fold (0.35 log units) above the measured one; the measured number falls inside the stated range.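

In this assay, cyclohexyl in place of cyclopentyl on an amide-type nitrogen gives an at least 1.7-fold lower number from compound 3 to compound 4 (0.25 log units; that floor lies within the scatter), so on the core of compound 3 the change joins a limit to a measured number, and the floor of the step lies within the scatter. For the compounds shown here, on the core of compound 2, the same change to compound 1 cannot be read, with a limit on both sides, so the two cores offer no pair of step sizes to compare. The data therefore do not show that the change carries from one core to the other with the same size or direction, nor that cyclohexyl truly lowers the number on either core.

The compounds shown leave open whether a benzyl group or a longer chain on that amide-type nitrogen would give a readable step on either core. They also leave open how an amine or a carboxylic acid at that place would read in this assay.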